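A few compounds are considered here, and "the series" means these few. Any claim that something is new, unique, unknown or untested is made for them only; others in the source may bear on it.

The compounds measured so far:
compound 1, `N#CC1=C(N)OC(c2c[nH]c3ccccc23)=C(C#N)C1c1cccc2ccccc12`, 7.7%;
compound 2, `N#CC1=C(N)OC(c2c[nH]c3ccccc23)=C(C#N)C1c1ccccc1`, 24.5%;
compound 3, `N#CC1=C(N)OC(c2c[nH]c3ccccc23)=C(C#N)C1c1ccc(F)cc1`, 22.4%.

In a functional assay, tested at 200 ug/mL (on this read-out lower numbers stand for a weaker effect and higher numbers for a stronger effect at the one concentration tested), compound 3 stands second highest of the three numbers. Its nearest neighbour is compound 2, the step of a number 2.1 percentage points lower from compound 2 to compound 3 (within the scatter) lying within the scatter; its furthest is compound 1, with a number 14.7 percentage points higher from compound 1 to compound 3 (beyond the scatter) beyond it. Compound 4, `N#CC1=C(N)OC(c2c[nH]c3ccccc23)=C(C#N)C1c1ccccc1Cl`, differs from compound 3 by 2-chlorophenyl in place of 4-fluorophenyl on a saturated ring carbon. Among the compounds with values here, the steps that exchange the whole aryl group, a number 16.8 percentage points higher from compound 1 to compound 2 (beyond the scatter) and a number 14.7 percentage points higher from compound 1 to compound 3 (beyond the scatter), were modest, and the one halogen step, a number 2.1 percentage points lower from compound 2 to compound 3 (within the scatter), stayed within the scatter. Within the data shown here, no measured step covers chlorine or this placement, so compound 4 is expected to move by a number 1.4 percentage points lower from compound 3 to compound 4 (within the scatter), not beyond the scatter. Compound 4 is estimated at 21%, between 8% and 34%.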

Compound 4, a percentage reported as activity, at one concentration (the size of the read-out at that concentration, not a potency): 14.5%
For compound 4 the middle estimate is 6.5 percentage points above the measured one; measured number inside the range.
By their numbers in this assay, from the lowest: compounds 1, 4, 3 and 2 (each within the scatter of the next, the first and the last beyond it).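

In this assay, the steps of a number 7.9 percentage points lower from compound 3 to compound 4 (within the scatter) and a number 10 percentage points lower from compound 2 to compound 4 (within the scatter) and also a number 6.8 percentage points higher from compound 1 to compound 4 (within the scatter) show that 2-chlorophenyl on the saturated ring carbon cannot be told apart from any of the three earlier aryl groups. Compound 4 thus lies within the scatter of both compound 1 and compound 2, although those two lie beyond the scatter of each other. Nothing at hand explains these numbers.

The compounds shown do not separate the effect of chlorine from that of its placement on the phenyl ring. They also leave open what an amine or a carboxylic acid on that ring would give.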